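The source may report more compounds than this note shows. Statements on the series, on what has been measured and on what is new or still open speak of the compounds shown alone.

For the measured compounds named here, only two compounds have numbers so far in a physicochemical assay for lipophilicity (a higher number here means a more lipophilic compound, a lower number a more polar compound), and their cores differ. Compound 2 (`CCCCCCCN(CCCCCSc1[nH]cnc2nncc1-2)C(=O)Nc1ccc(F)cc1F`) stands at 5.6 as the higher of the two. Compound 1 (`CCCCCCCN(CCCCCSc1nc(N)c2c[nH]nc2n1)C(=O)NC(C)C`) sits at 5.14 on the same scale, a gap beyond the scatter. Compound 3 (`CCCCCCCN(CCCCCSc1[nH]cnc2nncc1-2)C(=O)NC(C)C`) keeps the core of compound 2 and changes one group, with isopropyl in place of 2,4-difluorophenyl on an amide-type nitrogen. Going by the values given here, no measured pair shows this change alone, so its size has to be judged. Among the compounds with values here, the only guide is compound 1 (5.14), which also bears isopropyl on that nitrogen, though on another core. A fall beyond the scatter is therefore expected, and the estimated step is (a number 0.80 log units lower from compound 2 to compound 3 (beyond the scatter)). In this assay the estimate for compound 3 is 4.8 (expected range 4.3 to 5.3).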

Compound 3, partition coefficient: 5
For compound 3 the middle estimate is 0.20 log units below the measured one; the range from low to high includes it.
By their numbers in this assay, from the lowest: compounds 3 and 1 (each within the scatter of the next); then compound 2.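

In this assay, the change on the amide-type nitrogen now has a measured size on a single core: isopropyl in place of 2,4-difluorophenyl gives a number 0.60 log units lower from compound 2 to compound 3 (beyond the scatter), so this group alone can move the reading by more than the scatter. With isopropyl held constant, the change of group on the sulfur gives a number 0.14 log units lower from compound 1 to compound 3 (within the scatter), so these two cores cannot be told apart on this scale. No measurement here accounts for the size of either step.

As far as these compounds go, it remains open whether the step follows the ring or the two fluorines, which a plain phenyl or a cyclohexyl on that nitrogen could help separate. From the compounds shown here alone, the core of compound 1 appears only with isopropyl, so the same change remains untested on that core.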